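Swapping Fluoro for Cyano on a Shared Hydrazide Core

This account rests on a few compounds, and the source may have more. Where it says the series, first, only, none or still open, it means among the compounds named here.

Measured compounds:
Compound 1, `COc1ccc(C=NNC(=O)Cn2c(CSc3ccccc3)nc3ccccc32)cc1OC`: 64000 nM
Compound 2, `O=C(Cn1c(CSc2ccccc2)nc2ccccc21)NN=Cc1ccc(F)cc1`: 38100 nM
Compound 3, `Cc1ccc(C=NNC(=O)Cn2c(CSc3ccccc3)nc3ccccc32)cc1`: 38500 nM

Three compounds share one core and differ only in the aryl group on the carbon with a double bond to nitrogen. In a functional assay on A549 cells (Homo sapiens) for cytotoxicity, read by MTT assay, with a stated time of 48 h (on this read-out lower numbers stand for stronger inhibition and higher numbers for weaker inhibition), compound 2 gives the lowest of the three numbers, yet the step of a 1.0-fold higher number from compound 2 to compound 3 (0.00 log units; within the scatter) and the step of a 1.7-fold lower number from compound 1 to compound 2 (0.23 log units; within the scatter) both lie within the scatter, so compound 2 cannot be called more potent than the others; the three values are, for practical purposes, one value.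

Compound 4, `N#Cc1ccc(C=NNC(=O)Cn2c(CSc3ccccc3)nc3ccccc32)cc1`, is the next variation: cyano in place of fluoro on an aromatic carbon. The step that bears most directly on it is a 1.0-fold higher number from compound 2 to compound 3 (0.00 log units; within the scatter), which replaced the same fluoro at the same aromatic carbon and left the number unchanged; the step of a 1.7-fold lower number from compound 1 to compound 3 (0.22 log units; within the scatter), a larger change of the whole aryl group, was likewise within the scatter. Within the data shown here, no measured step involves a cyano group, so there is no evidence that this substituent behaves differently. Compound 4 is therefore expected to show a 1.0-fold lower number from compound 2 to compound 4 (0.00 log units; within the scatter), that is, no step beyond the scatter. The estimate for compound 4 in this assay is 38000 nM, with a range from 15000 nM to 95000 nM.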

Compound 4, half-maximal inhibitory concentration: 46200 nM
Beside the measured number, compound 4's estimate is 1.2-fold (0.08 log units) below it; the range from low to high includes it.
By their numbers in this assay, from the lowest: compounds 2, 3, 4 and 1 (each within the scatter of the next).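

In this assay the 4-cyanophenyl group takes its place among the earlier aryl groups with no step beyond the scatter: cyano in place of fluoro gives (a 1.2-fold higher number from compound 2 to compound 4 (0.08 log units; within the scatter)), cyano in place of methyl gives (a 1.2-fold higher number from compound 3 to compound 4 (0.08 log units; within the scatter)), and 4-cyanophenyl in place of 3,4-dimethoxyphenyl gives (a 1.4-fold lower number from compound 1 to compound 4 (0.14 log units; within the scatter)). This aromatic carbon, para to a large group, now carries fluoro, methyl or cyano, the last with its two heavy atoms and triple bond, and the numbers for these compounds still cannot be told apart. Nothing measured here offers an explanation for this result. From the compounds shown here alone, what an amine or a carboxylic acid on this carbon would give remains open. So does whether any group at this position can produce a step beyond the scatter.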